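Working notes: replacing 2-methoxyphenyl with 4-(dimethylamino)phenyl

This account rests on a few compounds, and the source may have more. Where it says the series, first, only, none or still open, it means among the compounds named here.

- compound 1 `COc1ccccc1/C=C(/SCc1ccc(F)cc1)C(=O)c1ccc(Br)cc1` gives 10000 nM
- compound 2 `COc1ccccc1/C=C(/Sc1ccc(C)cc1)C(=O)c1ccc(Br)cc1` gives 9000 nM

In a functional assay on DU-145 cells (Homo sapiens) for inhibition, read by trypan blue exclusion, with a stated time of 96 h (a lower number here means a stronger inhibitor of growth, a higher number a weaker inhibitor of growth), compound 1 cannot be separated from compound 2 . Among the compounds with values here, the only measured step is a 1.1-fold lower number from compound 1 to compound 2 (0.05 log units; within the scatter), and it concerns the group on a sulfur.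

Compound 3 `CN(C)c1ccc(/C=C(/SCc2ccc(F)cc2)C(=O)c2ccc(Br)cc2)cc1` keeps the group on sulfur of compound 1 and changes another place: 4-(dimethylamino)phenyl in place of 2-methoxyphenyl on a double-bonded chain carbon bound to a double-bonded chain carbon. Within the data shown here, no measured step touches this place, so the data give no size for it. A moderate shift to a lower number is expected, loosely estimated as a 2.5-fold lower number from compound 1 to compound 3 (0.40 log units; beyond the scatter). For compound 3 the estimated value is 4000 nM, with an expected range of 600 nM to 20000 nM.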

Compound 3, concentration for 50% growth inhibition: 50000 nM
Compound 3: the middle estimate sits 13-fold (1.10 log units) below what was measured, outside the stated range (above it).
By their numbers in this assay, from the lowest: compounds 2 and 1 (each within the scatter of the next); then compound 3.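

In this assay, the place on a double-bonded chain carbon bound to a double-bonded chain carbon now has a measured size: 4-(dimethylamino)phenyl in place of 2-methoxyphenyl gives a 5.0-fold higher number from compound 1 to compound 3 (0.70 log units; beyond the scatter). Unlike the earlier change on sulfur, this change lies beyond the scatter. No available evidence accounts for the step.

Still open, on these data alone, is whether plain phenyl or 4-methoxyphenyl at this place would stand with compound 1 or with compound 3. Also open, as far as these compounds go, is whether the step holds with the 4-methylphenyl on sulfur of compound 2.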